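The source may hold more compounds than are shown below. What is called first, only, known or untested is meant among the compounds shown, and "the series" means these compounds.

Measured so far:
- compound 1 `Nc1cc(N)c2nc(-c3ccccc3)c(NCc3ccc(Cl)c(Cl)c3)nc2c1`: 19100 nM
- compound 2 `Nc1cc(N)c2nc(-c3ccccc3)c(Sc3ccc(F)cc3)nc2c1`: < 100000 nM
- compound 3 `Nc1cc(N)c2nc(-c3ccccc3)c(Sc3ccc(Cl)c(Cl)c3)nc2c1`: < 100000 nM

Among the measured compounds shown here, in a functional assay on PC-3 cells (Homo sapiens) for inhibition, read by sulforhodamine B assay, with a stated time of 48 h (a lower number here means that less compound is tolerated, a higher number that more compound is tolerated), compound 1 gives 19100 nM and is the only compound in the set with a number rather than a limit. For compound 2 the value < 100000 nM is a limit of this assay and not a number. For compound 3 the value < 100000 nM is likewise a limit. For the measured compounds named here, the one measured step between compounds that differ in one place, a step that the two limits leave unreadable from compound 2 to compound 3, cannot be read in size, because the limit of < 100000 nM in this assay, at which 2 of the 3 values shown sit, is where both its ends sit.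

Compound 4 `COc1ccc(CNc2nc3cc(N)cc(N)c3nc2-c2ccccc2)cc1OC` is not yet measured. It differs from compound 1 in one place: 3,4-dimethoxyphenyl in place of 3,4-dichlorophenyl on a saturated chain carbon bound to a nitrogen on an aromatic ring. No measured step touches this change, since the only step shown concerns groups on a sulfur and is itself unreadable. The expectation for compound 4 therefore rests on compound 1 alone, which gives 19100 nM, and on the change from a halogenated ring to a dimethoxy ring at the same place. With nothing in the data to set a direction, no step beyond the usual scatter is expected. Compound 4 is expected to give about 25000 nM, in the range 7000 nM to 90000 nM. The expected step is a 1.3-fold higher number from compound 1 to compound 4 (0.12 log units; within the scatter).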

Compound 4, concentration lethal to 50% of the cells: 83200 nM
Beside the measured number, compound 4's estimate is 3.3-fold (0.52 log units) below it, within the range that was stated.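

In this assay, among the compounds shown here, replacing 3,4-dichlorophenyl with 3,4-dimethoxyphenyl on a saturated chain carbon bound to a nitrogen on an aromatic ring gives a 4.4-fold higher number from compound 1 to compound 4 (0.64 log units; beyond the scatter), the only readable step so far. This shows that the read-out responds to the groups on this aromatic ring, even though the leaving and entering groups both contain one six-membered aromatic ring of carbon only; the count of 0 hydrogen-bond acceptors in the leaving group against 2 in the entering group describes the change but does not explain it. The sulfur-linked compounds 2 and 3 each carry a limit and not a number, so the step between them cannot be read and gives no size to set against this one: the limit of < 100000 nM in this assay, at which 2 of the 4 values shown sit.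

As far as these compounds go, whether the higher number comes from losing the chlorine atoms or from gaining the methoxy groups remains open, and an unsubstituted phenyl on the same chain carbon would separate the two. Also open, from the compounds shown here alone, is how a carboxylic acid or a dimethylamino group on this ring would read, and whether 3,4-dimethoxyphenyl on a sulfur would give a readable number.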